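Swapping the Phenyl on the Ring Nitrogen for Tert-Butyl

The source may hold more compounds than are shown below. What is called first, only, known or untested is meant among the compounds shown, and "the series" means these compounds.

Three urea compounds built on one shared core have been tested in an assay on isolated protein for inhibition of STE20-like serine/threonine-protein kinase (Homo sapiens), read by thermal shift assay, tested at 10 uM; on this read-out lower numbers stand for weaker stabilisation of the target and higher numbers for stronger stabilisation of the target against heat. Compound 1 `CC(C)(C)c1cc(NC(=O)Nc2cc(C(F)(F)F)cc(C(F)(F)F)c2)n(-c2ccccc2)n1` gives 0 degrees C, the lowest of the three numbers. Among the compounds with values here, compound 2 `Cc1cc(C)cc(NC(=O)Nc2cc(C(C)(C)C)nn2-c2ccccc2)c1` gives 2.4 degrees C, and compound 3 `CC(C)(C)c1cc(NC(=O)Nc2ccccc2)n(-c2ccccc2)n1` gives 7.7 degrees C. The only measured step, a number 5.3 degrees C higher from compound 2 to compound 3 (beyond the scatter), concerns the group on the amide-type nitrogen, a different position from the one changed here. Compound 4 `CC(C)(C)c1cc(NC(=O)Nc2cc(C(F)(F)F)cc(C(F)(F)F)c2)n(C(C)(C)C)n1` differs from compound 1 by tert-butyl in place of phenyl on an aromatic nitrogen. Within the data shown here, no measured step bears directly on this change, so there is no firm ground for a shift in either direction. The expected step is therefore small, not clearly beyond the scatter: a number 0.50 degrees C higher from compound 1 to compound 4 (within the scatter). Compound 4 is expected to give 0.5 degrees C, within a range from -1.5 degrees C to 3 degrees C.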

Compound 4, shift of the target's melting temperature: -0.2 degrees C
Beside the measured number, compound 4's estimate is 0.70 degrees C above it; low and high end bracket the measured number.
By their numbers in this assay, from the lowest: compounds 4 and 1 (each within the scatter of the next); then compound 2; then compound 3.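

In this assay, putting tert-butyl in place of phenyl on the aromatic nitrogen gives a number 0.20 degrees C lower from compound 1 to compound 4 (within the scatter) and so leaves the reading essentially unchanged. At this position and on this core, a group with no ring and fewer heavy atoms serves no differently from phenyl. No available evidence explains this result.

On these data alone, the swap starts from compound 1, at 0 degrees C, so its effect on compound 3, at 7.7 degrees C, remains open. So does the outcome for a methyl group, or a longer chain ending in an amine, on this nitrogen.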